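Amide substituent variation on the shared core

The source may report more compounds than this note shows. Statements on the series, on what has been measured and on what is new or still open speak of the compounds shown alone.

Going by the values given here, compound 2 `CC(C)CCC(=O)Nc1c(C(O)(C(F)(F)F)C(F)(F)F)ccc2ccccc12` shows the lowest of the three numbers measured so far, giving 49 nM in an assay on LtK cells with ATP-sensitive inward rectifier potassium channel 11 (Homo sapiens) as the target; on this read-out higher numbers stand for an effect only at larger amounts of compound and lower numbers for an effect already at smaller amounts. Compound 1 `C/C=C/C(=O)Nc1c(C(O)(C(F)(F)F)C(F)(F)F)ccc2ccccc12` gives 72 nM; the step is a 1.5-fold lower number from compound 1 to compound 2 (0.17 log units; within the scatter). Compound 3 `O=C(Nc1c(C(O)(C(F)(F)F)C(F)(F)F)ccc2ccccc12)C1CCCC1` gives 495 nM; from compound 2 the step is a 10-fold higher number from compound 2 to compound 3 (1.00 log units; beyond the scatter), and from compound 1 it is a 6.9-fold higher number from compound 1 to compound 3 (0.84 log units; beyond the scatter). Compound 4 `O=C(Nc1c(C(O)(C(F)(F)F)C(F)(F)F)ccc2ccccc12)c1cccc(C(F)(F)F)c1` differs from compound 2 by 3-(trifluoromethyl)phenyl in place of isopentyl on a carbonyl carbon. Among the compounds with values here, no measured step brings an aromatic ring to this position, so guidance is thin; the one ring that did enter here, in compound 3, came with a higher number. The expected step is therefore a 6.1-fold higher number from compound 2 to compound 4 (0.79 log units; beyond the scatter), with wide uncertainty. Compound 4 is estimated at 300 nM, within 60 nM to 1500 nM.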

Compound 4, half-maximal effective concentration: 84 nM
Compound 4: middle estimate off by 3.6-fold (0.55 log units), on the high side, within the range that was stated.
By their numbers in this assay, from the lowest: compounds 2, 1 and 4 (each within the scatter of the next); then compound 3.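

An aromatic ring on this carbonyl carbon keeps the number in the range of the open-chain amides in this assay: 3-(trifluoromethyl)phenyl in place of isopentyl gives a 1.7-fold higher number from compound 2 to compound 4 (0.23 log units; within the scatter) and in place of prop-1-en-1-yl gives a 1.2-fold higher number from compound 1 to compound 4 (0.07 log units; within the scatter). A ring at this position therefore does not by itself bring the higher number of compound 3, as 3-(trifluoromethyl)phenyl in place of cyclopentyl gives a 5.9-fold lower number from compound 3 to compound 4 (0.77 log units; beyond the scatter). No evidence at hand explains why cyclopentyl stands apart. As far as these compounds go, whether an unsubstituted phenyl or a pyridine ring at this position would match compound 4 remains open, as does whether a cyclohexyl ring would follow compound 3.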